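Swapping the Phenyl Group: What to Expect of Compound 3

A few compounds are considered here, and "the series" means these few. Any claim that something is new, unique, unknown or untested is made for them only; others in the source may bear on it.

compound 1 `O=C(Cc1csc2nc(-c3ccc(Br)cc3)cn12)N/N=C/c1ccccc1O`: 3470 nM
compound 2 `O=C(Cc1csc2nc(-c3ccc(Br)cc3)cn12)N/N=C/c1ccc(O)cc1`: 14500 nM

In a functional assay on HCC 2998 cells (Homo sapiens) for inhibition, read by sulforhodamine B assay, with a stated time of 48 h (on this read-out higher numbers stand for weaker inhibition of growth and lower numbers for stronger inhibition of growth), compound 2 gives 14500 nM, the higher of the two numbers and so the weaker growth inhibition of the pair. The next compound, compound 3 `COc1cccc(OC)c1/C=N/NC(=O)Cc1csc2nc(-c3ccc(Br)cc3)cn12`, keeps the shared core and differs from compound 2 in one place: 2,6-dimethoxyphenyl in place of 4-hydroxyphenyl on a carbon with a double bond to nitrogen. Within the data shown here, only one measured step bears on this change: a 4.2-fold higher number from compound 1 to compound 2 (0.62 log units; beyond the scatter). That step is modest but beyond the scatter, and it shows that swapping the group at this same place can move the number. Among the measured compounds shown here, it compares only two hydroxyphenyl groups, however, and no measured compound carries a 2,6-dimethoxyphenyl group, so it is a rough guide at best. With compound 2 at the high end at 14500 nM, a move toward lower numbers seems likelier than a further rise. The expected result is a 2.2-fold lower number from compound 2 to compound 3 (0.35 log units; beyond the scatter), a change toward stronger inhibition in this assay. For compound 3 the estimated value is 6500 nM, with an expected range from 2200 nM to 19000 nM.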

Compound 3, concentration for 50% growth inhibition: 10000 nM
Compound 3: the middle estimate sits 1.5-fold (0.19 log units) below what was measured; low and high end bracket the measured number.
By their numbers in this assay, from the lowest: compound 1; then compounds 3 and 2 (each within the scatter of the next).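

Placing a 2,6-dimethoxyphenyl group on the carbon with a double bond to nitrogen gives a 1.5-fold lower number from compound 2 to compound 3 (0.16 log units; within the scatter) in this assay, so a larger group that has lost the hydrogen-bond donor of the 4-hydroxyphenyl group reads much like it here. Among these compounds, the same group set against the 2-hydroxyphenyl group gives a 2.9-fold higher number from compound 1 to compound 3 (0.46 log units; beyond the scatter), which leaves compound 1 as the one compound of the three with a number clearly lower than both others, and shows that the presence or absence of a hydrogen-bond donor does not by itself sort these compounds, since compound 2 carries one and compound 3 carries none. Nothing measured here gives a reason for this behaviour.

The compounds shown leave open whether the lower number of compound 1 is tied to its hydroxyl group at all, or whether a phenyl ring carrying a single methoxy group, an amine or a carboxylic acid would read the same way. They also leave open how an unsubstituted phenyl group would compare with these three, so the size of the effect of any one group at this position remains unsettled.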